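Pyrrolidin-1-yl for 4-Methylpiperazin-1-yl on a Shared Core

The compounds below may be only part of what the source reports. "The series", "measured", "known", "first", "only" and "open" are said of these compounds alone.

Three compounds have been measured in a functional assay on HepG2 cells (Homo sapiens) for antiproliferative activity, read by MTT assay, with a stated time of 72 h; a lower number here means a stronger inhibitor, a higher number a weaker inhibitor:
Compound 1 `CN1CCN(CCCn2cccc2/C=N/NC(=O)Nc2ccc(Oc3ccnc4[nH]ccc34)c(F)c2)CC1` gives 2740 nM.
Compound 2 `O=C(N/N=C/c1cccn1CCCN1CCCC1)Nc1ccc(Oc2ccnc3[nH]ccc23)c(F)c1` gives 3500 nM.
Compound 3 `CN1CCN(CCCn2cccc2/C=N/NC(=O)Nc2ccc(Oc3ccnc4[nH]ccc34)cc2)CC1` gives 2760 nM.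

Compound 2 differs from compound 1 in one place, (pyrrolidin-1-yl in place of 4-methylpiperazin-1-yl on a saturated chain carbon, three bonds along the chain from an aromatic nitrogen), and this change gave a 1.3-fold higher number from compound 1 to compound 2 (0.11 log units; within the scatter). Compound 3 differs from compound 1 by hydrogen in place of fluoro on an aromatic carbon, which gave a 1.0-fold higher number from compound 1 to compound 3 (0.00 log units; within the scatter). Compound 4 `O=C(N/N=C/c1cccn1CCCN1CCCC1)Nc1ccc(Oc2ccnc3[nH]ccc23)cc1` has not yet been measured. It differs from compound 3 by pyrrolidin-1-yl in place of 4-methylpiperazin-1-yl on a saturated chain carbon, three bonds along the chain from an aromatic nitrogen; the place is the same word for word as in the first pair, so this is the same change made on the core of compound 3 instead of compound 1. Because the same change gave a 1.3-fold higher number from compound 1 to compound 2 (0.11 log units; within the scatter), a step of a 1.3-fold higher number from compound 3 to compound 4 (0.10 log units; within the scatter) is expected in this assay. Compound 4 is therefore estimated at 3500 nM, with a likely range from 1800 nM to 7000 nM.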

Compound 4, half-maximal inhibitory concentration: 1420 nM
Beside the measured number, compound 4's estimate is 2.5-fold (0.39 log units) above it, outside the stated range (below it).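

Made on the core of compound 3, the change to pyrrolidin-1-yl gave a 1.9-fold lower number from compound 3 to compound 4 (0.29 log units; within the scatter), and this step does not differ from the earlier one: the same change on two cores in this assay, a 1.3-fold higher number (0.11 log units; within the scatter) from compound 1 to compound 2 and a 1.9-fold lower number (0.29 log units; within the scatter) from compound 3 to compound 4, 2.5-fold (0.39 log units) apart, within the scatter of two such steps Hydrogen in place of fluoro gave a 2.5-fold lower number from compound 2 to compound 4 (0.39 log units; beyond the scatter), which lies beyond the scatter on its own but still does not differ from its earlier counterpart: the same change on two cores in this assay, a 1.0-fold higher number (0.00 log units; within the scatter) from compound 1 to compound 3 and a 2.5-fold lower number (0.39 log units; beyond the scatter) from compound 2 to compound 4, 2.5-fold (0.39 log units) apart, within the scatter of two such steps In this assay, neither change is thus shown to depend on the core, but with only two pairs for each change, this does not show that the steps are equal, and a real core effect of this size cannot be told from scatter.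

As far as these compounds go, it remains open how either step would behave with another amine on the chain, such as morpholin-4-yl or piperidin-1-yl. A longer chain, or chloro in place of fluoro, is also left open.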